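A few compounds are considered here, and "the series" means these few. Any claim that something is new, unique, unknown or untested is made for them only; others in the source may bear on it.

Measured compounds:
compound 1, `CCc1ccc(-c2nn3cc(-c4cccc(N)c4)nc3s2)cc1` — 22000 nM
compound 2, `Nc1cccc(-c2cn3nc(Cc4ccccc4)sc3n2)c1` — 37000 nM

Going by the values given here, only two compounds have been measured in a functional assay on CCRF-CEM cells (Homo sapiens) for inhibition, read by cell counting, with a stated time of 3 days (a higher number here means a weaker inhibitor, a lower number a stronger inhibitor), and compound 2 gives the higher of the two numbers. Its nearest neighbour is compound 1, whose number is lower, but the gap between them lies within the scatter of repeated measurements, so the two cannot be told apart on these data. Both share the same aminophenyl group and the same fused core; they differ in how the second ring is joined to that core.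

Compound 3, `Nc1cccc(-c2cn3nc(-c4ccccc4)sc3n2)c1`, is the next compound to be measured in this assay. Compared with compound 2 it carries phenyl in place of benzyl on an aromatic carbon. The change removes the single carbon that links the ring to the core, leaving the ring joined directly.

Among the compounds with values here, no measured pair shows the effect of this change, so the expectation rests only on compound 2 and its neighbour. The step from compound 2 to compound 3 is expected to be small, a 1.5-fold lower number from compound 2 to compound 3 (0.17 log units; within the scatter), and not clearly beyond the scatter. Compound 3 is therefore estimated at 25000 nM, with a range from 8000 nM to 80000 nM.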

Compound 3, half-maximal inhibitory concentration: 33000 nM
For compound 3 the middle estimate is 1.3-fold (0.12 log units) below the measured one, and the stated range covers the measured number.
By their numbers in this assay, from the lowest: compounds 1, 3 and 2 (each within the scatter of the next).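

In this assay, the phenyl in place of benzyl on the aromatic carbon of the five-membered ring gives a 1.1-fold lower number from compound 2 to compound 3 (0.05 log units; within the scatter), so this first direct test of that change shows that dropping the linking carbon leaves the two compounds indistinguishable. The second step, hydrogen in place of ethyl on an aromatic carbon, gives a 1.5-fold higher number from compound 1 to compound 3 (0.18 log units; within the scatter), so the ethyl group likewise makes no difference that can be told from the scatter, and neither change separates any of the three compounds shown. Nothing available explains this lack of separation, as no supporting information bears on the result.

The compounds shown leave open whether any group at these places could move the number beyond the scatter, for instance a longer chain in place of ethyl, or an amine or a carboxylic acid on the aromatic carbon that carries phenyl or benzyl. They also leave open what the aminophenyl group contributes, as it is the same in all three compounds, and a compound with an amide or a hydroxyl group in place of its amine would be needed to address that.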